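This account rests on a few compounds, and the source may have more. Where it says the series, first, only, none or still open, it means among the compounds named here.

Measured compounds: compound 1 `Cn1ccc2cc(-c3ccc4oc(NC5CCCCC5)nc4c3)ccc21`, compound 2 `c1cc2c(ccn2C2COC2)cc1-c1ccc2oc(NC3CCCCC3)nc2c1` and compound 3 `Cn1ncc2c(-c3ccc4oc(NC5CCCCC5)nc4c3)cccc21`. In an assay on HEK293 cells for inhibition of Fatty-acid amide hydrolase 1 (Homo sapiens), read by fluorescence (on this read-out lower numbers stand for stronger inhibition and higher numbers for weaker inhibition), compound 1 gives 911 nM, compound 2 gives 579 nM, and compound 3 gives 52 nM.

Among these three numbers compound 1 stands highest. Compound 2 lies close to it, with a 1.6-fold lower number from compound 1 to compound 2 (0.20 log units; within the scatter), while compound 3 sits far lower. Compound 4 `Cn1ccc2cc(-c3ccc4oc(N5CCn6cccc6C5)nc4c3)ccc21` has not yet been measured. It departs from compound 1 in one place: a group of 9 heavy atoms (7 carbon, 2 nitrogen; one five-membered aromatic ring with 1 hetero atom, one six-membered non-aromatic ring with 2 hetero atoms) in place of a group of 7 heavy atoms (6 carbon, 1 nitrogen; one six-membered non-aromatic ring of carbon only), on an aromatic carbon. The group that leaves carries a hydrogen-bond donor; the group that enters carries none. Among the compounds with values here, the only measured step swaps the group on the aromatic nitrogen and leaves this part of the molecule untouched, and compound 3 differs from compound 1 in more than one place, so no measured step bears on this change. With nothing to anchor the direction, a modest move is expected, with wide uncertainty. For compound 4 the estimated result is 1500 nM, within 400 nM to 6000 nM, which is expected to mean a step of a 1.6-fold higher number from compound 1 to compound 4 (0.22 log units; within the scatter).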

Compound 4, half-maximal inhibitory concentration: 42 nM
Compound 4: middle estimate off by 36-fold (1.55 log units), on the high side, outside the stated range (below it).
By their numbers in this assay, from the lowest: compounds 4 and 3 (each within the scatter of the next); then compounds 2 and 1 (each within the scatter of the next).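

On the aromatic carbon of the five-membered ring with 1 nitrogen and 1 oxygen, replacing cyclohexylamino with the two-ring group gives a 22-fold lower number from compound 1 to compound 4 (1.34 log units; beyond the scatter) in this assay. This position can therefore move the number far more than the change on the aromatic nitrogen did, and a group with no hydrogen-bond donor is compatible with a low number here. No measurement on hand explains the size of this step.

As far as these compounds go, whether the missing donor or the added rings matter more stays open; a simple piperidine ring at this position would help separate the two. From the compounds shown here alone, it is also open whether the two-ring group would lower the number further on the core of compound 3.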